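Swapping a benzyl for an aryl on the ring nitrogen

The compounds below may be only part of what the source reports. "The series", "measured", "known", "first", "only" and "open" are said of these compounds alone.

Compound 1, `Clc1ccc(-n2cc(COc3cccc4cnc(Nc5cccc(Cl)c5)nc34)nn2)cc1`: in a functional assay on PC-3 cells (Homo sapiens) for cytotoxicity, read by cell counting, with a stated time of 48 h (a higher number here means a weaker inhibitor, a lower number a stronger inhibitor), compound 1 gives > 25000 nM, which is a limit of the assay.
Compound 2, `COc1ccccc1-n1cc(COc2cccc3cnc(Nc4cccc(Cl)c4)nc23)nn1`: in this assay compound 2 gives 8000 nM.
Compound 3, `Clc1cccc(Nc2ncc3cccc(OCc4cn(Cc5c(Cl)cccc5Cl)nn4)c3n2)c1`: in this assay compound 3 gives 7000 nM.

Compound 3 holds the lowest of the two numbers shown, but compound 2 sits within the scatter of it (a 1.1-fold lower number from compound 2 to compound 3 (0.06 log units; within the scatter)), so the two cannot be ordered. Against compound 1 the step is larger, an at least 3.5-fold lower number from compound 1 to compound 3 (0.55 log units; beyond the scatter), and since that value is a limit (the limit of > 25000 nM in this assay, at which 1 of the 3 values shown sits) the step is a minimum.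

Compound 4, `Clc1cccc(Nc2ncc3cccc(OCc4cn(-c5cc(Cl)cc(Cl)c5)nn4)c3n2)c1`, differs from compound 3 in one place: 3,5-dichlorophenyl in place of 2,6-dichlorobenzyl on an aromatic nitrogen. For the measured compounds named here, the steps that bear on this are those changing the group on the aromatic nitrogen: an at least 3.1-fold lower number from compound 1 to compound 2 (0.49 log units; beyond the scatter) and an at least 3.5-fold lower number from compound 1 to compound 3 (0.55 log units; beyond the scatter). Going by the values given here, of the two compounds carrying an aryl ring directly on that nitrogen, one gives a limit and one a moderate number, and no measured compound carries 3,5-dichlorophenyl. A step back toward the weaker side is therefore expected in this assay. Compound 4 is expected at 12000 nM, within a range from 4000 nM to 40000 nM. For compound 4 this means an expected 1.7-fold higher number from compound 3 to compound 4 (0.23 log units; within the scatter).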

Compound 4, half-maximal inhibitory concentration: 8000 nM
Compound 4: middle estimate off by 1.5-fold (0.18 log units), on the high side, within the range that was stated.
By their numbers in this assay, from the lowest: compounds 3, 2 and 4 (each within the scatter of the next). At a limit, above all of these: compound 1.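

In this assay, an aryl ring set directly on the aromatic nitrogen does no harm in itself, since 3,5-dichlorophenyl in place of 2,6-dichlorobenzyl gives a 1.1-fold higher number from compound 3 to compound 4 (0.06 log units; within the scatter). For the compounds shown here, two differently substituted aryl rings also cannot be told apart, with no change at the digits printed from compound 2 to compound 4 (within the scatter), so compound 1, with 4-chlorophenyl, is the one aryl compound that goes against this, and the change away from it gives an at least 3.1-fold lower number from compound 1 to compound 4 (0.49 log units; beyond the scatter). That last step is a minimum, not a measured size: the limit of > 25000 nM in this assay, at which 1 of the 4 values shown sits.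

The compounds shown do not tell what sets compound 1 apart from the other three. From the compounds shown here alone, it also stays open whether an aryl ring carrying an amine or a carboxylic acid, or a longer chain on that nitrogen, would move the number away from where compounds 2, 3 and 4 sit.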